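The compounds below may be only part of what the source reports. "The series", "measured", "known", "first", "only" and "open" are said of these compounds alone.

Compound 1 `CNC(=O)c1cc(-c2cnc(NCc3c(F)ccc4c3CCO4)c3cn[nH]c(=O)c23)n(C)n1` was examined in an ADME assay on microsomes from liver (Homo sapiens) for metabolic stability, read by LC-MS, using NADPH, with stated times of 5 min and 30 min, tested at 1 uM; on this read-out lower numbers stand for slow clearance and higher numbers for fast clearance. In this assay compound 1 gives < 3 mL.min-1.g-1, which is a limit of the assay rather than a number, as the limit of < 3 mL.min-1.g-1 in this assay, at which 1 of the 3 values shown sits, records. Two further compounds built on the core of compound 2 were measured alongside: compound 2 `O=C(Nc1ccccc1)c1cnc(NCc2c(F)ccc3c2CCO3)n2cnnc12` gives 14 mL.min-1.g-1 in this assay, and compound 3 `CN(c1ccccc1)c1cnc(NCc2c(F)ccc3c2CCO3)n2cnnc12` gives 55 mL.min-1.g-1. Between them lies a 3.9-fold higher number from compound 2 to compound 3 (0.59 log units; beyond the scatter). Compound 4 `CNC(=O)c1ncc(-c2cnc(NCc3c(F)ccc4c3CCO4)c3cn[nH]c(=O)c23)n1C` differs from compound 1 by 1-methyl-2-(methylcarbamoyl)-1H-imidazol-5-yl in place of 1-methyl-3-(methylcarbamoyl)-1H-pyrazol-5-yl on an aromatic carbon. No measured step covers this change; the one step shown concerns another change on another core and offers no guide. With compound 1 sitting at a limit in this assay, the expected step is an at least 1.3-fold higher number from compound 1 to compound 4 (0.12 log units; that floor lies within the scatter), within the scatter. Compound 4 is therefore estimated at 4 mL.min-1.g-1, with a range from 1 mL.min-1.g-1 to 15 mL.min-1.g-1.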

Compound 4, intrinsic clearance in microsomes: 24 mL.min-1.g-1
Compound 4: the middle estimate sits 6.0-fold (0.78 log units) below what was measured; measured number above the stated range.
By their numbers in this assay, from the lowest: compounds 2 and 4 (each within the scatter of the next); then compound 3. At a limit, below all of these: compound 1.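

With the same atoms joined differently, 1-methyl-2-(methylcarbamoyl)-1H-imidazol-5-yl in place of 1-methyl-3-(methylcarbamoyl)-1H-pyrazol-5-yl gives, in this assay, an at least 8.0-fold higher number from compound 1 to compound 4 (0.90 log units; beyond the scatter). Thus clearance on this core responds to how this five-membered aromatic ring is arranged, even with its atom counts unchanged, which the earlier compounds could not show. Only a floor of that step can be read: the limit of < 3 mL.min-1.g-1 in this assay, at which 1 of the 4 values shown sits.

From the compounds shown here alone, whether the step would persist with a carboxylic acid or an ethylcarbamoyl group in place of methylcarbamoyl stays open.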